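The source may hold more compounds than are shown below. What is called first, only, known or untested is meant among the compounds shown, and "the series" means these compounds.

Compound 1 `COc1ccc(/C=C/c2cc(OC)cc(OC)c2/C=C/C(=O)N2CCCC2)cc1` and compound 2 `COc1ccc(/C=C/c2cc(OC)cc(OC)c2/C=C/C(=O)N2CCC(c3ccccc3)CC2)cc1` share one core and differ only in the ring on the carbonyl carbon. In a functional assay on MCF7 cells (Homo sapiens) for inhibition, read by MTT assay, with a stated time of 48 h (a higher number here means a weaker inhibitor, a lower number a stronger inhibitor), compound 1 gives 4200 nM, and compound 2 gives 4230 nM; compound 1 thus has the lowest of the two numbers shown, with a 1.0-fold higher number from compound 1 to compound 2 (0.00 log units; within the scatter). Compound 3 `COc1ccc(/C=C/c2cc(OC)cc(OC)c2/C=C/C(=O)N2CCC(Cl)CC2)cc1` changes compound 1 by 4-chloropiperidin-1-yl in place of pyrrolidin-1-yl on a carbonyl carbon. Among the compounds with values here, the one measured step on this carbonyl carbon bears on it and was a 1.0-fold higher number from compound 1 to compound 2 (0.00 log units; within the scatter), so no step beyond the scatter is expected in this assay, with no change at the digits printed from compound 1 to compound 3 (within the scatter). Compound 3 is therefore estimated at 4200 nM, within 2000 nM to 9000 nM.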

Compound 3, half-maximal inhibitory concentration: 4950 nM
Compound 3: the middle estimate sits 1.2-fold (0.07 log units) below what was measured, and the stated range covers the measured number.
By their numbers in this assay, from the lowest: compounds 1, 2 and 3 (each within the scatter of the next).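

In this assay, replacing pyrrolidin-1-yl with 4-chloropiperidin-1-yl on the carbonyl carbon gives a 1.2-fold higher number from compound 1 to compound 3 (0.07 log units; within the scatter). Chloro in place of phenyl on the saturated ring carbon gives a 1.2-fold higher number from compound 2 to compound 3 (0.07 log units; within the scatter), so a substituent other than phenyl on the six-membered ring also leaves the number level, and all three rings shown on this carbonyl carbon read alike. No measured evidence accounts for this. The compounds shown leave open whether an amine or a carboxylic acid on that ring would give a step beyond the scatter. They also leave open whether an open-chain dimethylamino group on the carbonyl carbon would do so.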